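The source may report more compounds than this note shows. Statements on the series, on what has been measured and on what is new or still open speak of the compounds shown alone.

Three compounds have been measured in an assay for inhibition of epoxide hydrolase 1 (Homo sapiens), read by fluorescence, using microsomes; on this read-out higher numbers stand for weaker inhibition and lower numbers for stronger inhibition:

- compound 1 `O=C(NC(=S)Nc1ccc(Oc2ccccc2)cc1)c1ccccc1`; in this assay compound 1 gives 2100 nM
- compound 2 `CC(=O)NC(=S)Nc1ccc(Cl)cc1`; in this assay compound 2 gives 2210 nM
- compound 3 `O=C(NC(=S)Nc1ccccc1)c1ccccc1`; in this assay compound 3 gives 1290 nM

Compound 3 carries the smallest of the three numbers, but the spread is narrow: the step of a 1.6-fold lower number from compound 1 to compound 3 (0.21 log units; within the scatter) lies within the scatter, and compound 2 sits at a similar small distance from compound 3, so none of the three can be called stronger or weaker than another.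

Compound 4 `O=C(NC(=S)Nc1ccc(Cl)cc1)c1ccccc1` is reached from compound 3 by one change, (chloro in place of hydrogen on an aromatic carbon). Among the compounds with values here, the only measured one-place step bearing on this position is a 1.6-fold lower number from compound 1 to compound 3 (0.21 log units; within the scatter), where a large group was removed from that same aromatic carbon without moving the number beyond the scatter. Within the data shown here, compound 2 already carries a chloro at that position, but its remaining structure differs from compound 3 in a second place, so its value and that of compound 3 show only that the two numbers lie close together. On this basis no step beyond the scatter is expected in this assay, in either direction, and the expected step of a 1.2-fold higher number from compound 3 to compound 4 (0.07 log units; within the scatter) is small. Compound 4 is therefore estimated at 1500 nM, with a range from 600 nM to 4000 nM.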

Compound 4, half-maximal inhibitory concentration: 1640 nM
Compound 4: middle estimate off by 1.1-fold (0.04 log units), on the low side; measured number inside the range.
By their numbers in this assay, from the lowest: compounds 3, 4, 1 and 2 (each within the scatter of the next).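

In this assay, within the data shown here, the step of a 1.3-fold higher number from compound 3 to compound 4 (0.10 log units; within the scatter) gives the first direct reading of chloro in place of hydrogen on this aromatic carbon, and it stays within the scatter. The step of a 1.3-fold lower number from compound 1 to compound 4 (0.11 log units; within the scatter) reads the same way for chloro in place of phenoxy, so with the earlier step from compound 1 to compound 3, hydrogen, chloro and phenoxy on this carbon cannot be told apart, whatever their difference in size. Compound 4 also opens a one-place comparison at the carbonyl carbon, which compound 2 and compound 3 could not give as they differ in two places: the step of a 1.3-fold lower number from compound 2 to compound 4 (0.13 log units; within the scatter) for phenyl in place of methyl is likewise within the scatter, and nothing shown here offers a reason for this lack of separation.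

Whether any group on the aromatic carbon moves the number beyond the scatter stays open, since an amine, a carboxylic acid or a methoxy group has no reading there among these compounds. At the carbonyl carbon only methyl and phenyl appear, so a longer chain or an amine in that place remains an open question.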